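Compound 3: pyridin-2-yl on the oxygen

The compounds below may be only part of what the source reports. "The series", "measured", "known", "first", "only" and "open" are said of these compounds alone.

In an ADME assay on the whole organism (strain Sprague-Dawley) with Rattus norvegicus as the target, at a dose of 1 mg/kg by the intravenous route (a higher number here means that the compound lasts longer, a lower number that the compound disappears faster), compound 1 (`CC(C)(C)C#Cc1cc(N(C(=O)[C@H]2CC[C@H](C)CC2)[C@H]2CC[C@H](Oc3cccnc3)CC2)c(C(=O)O)s1`) gives 3.4 h, and compound 2 (`CC(C)(C)C#Cc1cc(N(C(=O)[C@H]2CC[C@H](C)CC2)[C@H]2CC[C@H](Oc3nccs3)CC2)c(C(=O)O)s1`) gives 2.8 h. For the measured compounds named here, these two values lie within the scatter of each other, so compound 2 holds no distinct place on the numbers so far.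

Compound 3 (`CC(C)(C)C#Cc1cc(N(C(=O)[C@H]2CC[C@H](C)CC2)[C@H]2CC[C@H](Oc3ccccn3)CC2)c(C(=O)O)s1`) carries pyridin-2-yl in place of 1,3-thiazol-2-yl on an oxygen on a saturated carbon. Going by the values given here, one measured step bears on this change: a 1.2-fold lower number from compound 1 to compound 2 (0.08 log units; within the scatter). That step brings in the same 1,3-thiazol-2-yl at the same place, in exchange for pyridin-3-yl, and it stays within the scatter. The evidence is thin, since it rests on two compounds and no measurement with pyridin-2-yl exists yet. Even so, the one exchange seen at this place gives no reason to expect a step beyond the scatter in this assay, and no direction is favoured. The expected change is small: a 1.1-fold higher number from compound 2 to compound 3 (0.04 log units; within the scatter). For compound 3 the estimated value is 3.1 h, with an expected range from 1.8 h to 5.2 h.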

Compound 3, mean residence time: 5 h
Compound 3: middle estimate off by 1.6-fold (0.21 log units), on the low side, and the stated range covers the measured number.
By their numbers in this assay, from the lowest: compounds 2, 1 and 3 (each within the scatter of the next).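

In this assay the place on the oxygen now holds three aromatic rings, and the new steps show that the comparison reaches beyond a single exchange. Pyridin-2-yl in place of 1,3-thiazol-2-yl gives a 1.8-fold higher number from compound 2 to compound 3 (0.25 log units; within the scatter) and so a six-membered aromatic ring with 1 hetero atom for a five-membered one with 2 hetero atoms leaves the read-out within the scatter. Pyridin-2-yl in place of pyridin-3-yl gives a 1.5-fold higher number from compound 1 to compound 3 (0.17 log units; within the scatter) and this first comparison of two pyridinyl groups at the place also stays within the scatter, while no measurement on these compounds other than this read-out is available to account for the numbers.

Going by these compounds, all three compounds carry an aromatic ring on the oxygen, so it remains open whether a plain alkyl chain, or a saturated ring bearing an amine or a carboxylic acid, would give a step beyond the scatter at this place. On these data alone, the rest of the core is the same in all three, so it is also open whether the same exchanges would stay within the scatter with a different group in place of the tert-butyl-bearing alkyne.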